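Removing the tert-butyl group in a weakly active pair

The compounds below may be only part of what the source reports. "The series", "measured", "known", "first", "only" and "open" are said of these compounds alone.

In a functional assay on A-431 cells (Homo sapiens) for inhibition, read by MTT assay, with a stated time of 72 h (on this read-out lower numbers stand for stronger inhibition and higher numbers for weaker inhibition), compound 1 `Fc1ccc(-c2nnc(SCCCN3CCN(c4nc5ccccc5o4)CC3)o2)cc1` gives 136000 nM. Within the data shown here, on the same measure, compound 2 `CC(C)(C)Oc1ccc(-c2nnc(SCCCN3CCN(c4nc5ccccc5o4)CC3)o2)cc1` gives 65800 nM, the lower of the two numbers and so the stronger result, although only two compounds have been measured.

The next compound, compound 3 `Oc1ccc(-c2nnc(SCCCN3CCN(c4nc5ccccc5o4)CC3)o2)cc1`, differs from compound 2 in one place: hydrogen in place of tert-butyl on an oxygen on an aromatic ring, so tert-butoxy becomes hydroxy (hydrogen in place of tert-butyl on an oxygen on an aromatic ring).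

Among the measured compounds shown here, only one measured step bears on this change: a 2.1-fold lower number from compound 1 to compound 2 (0.32 log units; beyond the scatter), which came from tert-butoxy in place of fluoro on an aromatic carbon. For the measured compounds named here, no measured compound carries hydroxy, so this step is only a rough guide to size. With tert-butoxy gone, part of that modest difference may be lost, so a small move towards a higher number is expected in this assay, perhaps no larger than the scatter. The expected change is a 1.7-fold higher number from compound 2 to compound 3 (0.22 log units; within the scatter). For compound 3 the estimated value is 110000 nM, with a range from 45000 nM to 280000 nM.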

Compound 3, half-maximal inhibitory concentration: 117000 nM
Estimate against measurement, compound 3: 1.1-fold (0.03 log units) below; measured number inside the range.
By their numbers in this assay, from the lowest: compounds 2, 3 and 1 (each within the scatter of the next, the first and the last beyond it).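

Taking the tert-butyl group off the oxygen to leave hydroxy gives, in this assay, a 1.8-fold higher number from compound 2 to compound 3 (0.25 log units; within the scatter), so this change cannot be told apart from the ordinary spread of repeated measurements. Swapping fluoro for hydroxy on the same aromatic carbon gives a 1.2-fold lower number from compound 1 to compound 3 (0.07 log units; within the scatter), so these two groups cannot be separated either, and hydroxy sits within the scatter of both fluoro and tert-butoxy, even though the modest step between those two lies beyond it; the earlier pair alone, with nothing measured between its two ends, could not show how little separates the groups at this position. No supporting measurement is available to explain why the numbers fall as they do.

Going by these compounds, whether a methoxy group, an amine or a carboxylic acid on this aromatic carbon would give a number clearly apart from these three remains open. Also open, on these data alone, is whether changes elsewhere, such as a longer chain in place of the one in the shared core, would move the numbers more than any group at this position has so far.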